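The source may report more compounds than this note shows. Statements on the series, on what has been measured and on what is new or still open speak of the compounds shown alone.

Measured so far:
compound 1 `CCN(CCNC(=O)c1cc(Cl)c(N)cc1OC)Cc1ccoc1`: 3 mg/kg
compound 2 `COc1cc(N)c(Cl)cc1C(=O)NCCN(C)C(C)c1ccccc1`: 1 mg/kg

In a functional assay on the whole organism with Rattus norvegicus as the target (a lower number here means that less compound is needed, a higher number that more compound is needed for the effect), compound 1 gives 3 mg/kg, the higher of the two numbers, while compound 2 gives 1 mg/kg. That gap lies beyond the usual scatter, so compound 1 currently stands as the compound needing more for the effect.

Compound 3 `CCN(CCNC(=O)c1cc(Cl)c(N)cc1OC)Cc1cccc(OC)c1` is not yet measured. It has 3-methoxyphenyl in place of furan-3-yl on a saturated chain carbon bound to an amine nitrogen.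

For the measured compounds named here, no measured step covers this change, so the expectation rests only on compound 1 at 3 mg/kg and compound 2 at 1 mg/kg. The expected 1.5-fold lower number from compound 1 to compound 3 (0.18 log units; within the scatter) is small, toward a lower number, and is not expected to clear the scatter. For compound 3 the estimated value is 2 mg/kg, with an expected range from 0.6 mg/kg to 6 mg/kg.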

Compound 3, dose for half-maximal effect: 1 mg/kg
Beside the measured number, compound 3's estimate is 2.0-fold (0.30 log units) above it, within the range that was stated.
By their numbers in this assay, from the lowest: compounds 2 and 3 (each within the scatter of the next); then compound 1.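

In this assay, for the compounds shown here, the saturated chain carbon bound to an amine nitrogen responds to the group it carries: 3-methoxyphenyl in place of furan-3-yl gives a 3.0-fold lower number from compound 1 to compound 3 (0.48 log units; beyond the scatter) and this modest step is the first single-place change. The position accepts 8 heavy atoms in place of 5 without any loss in this read-out, while the counts of hydrogen-bond donors and acceptors stay the same. No measurement at hand accounts for the step.

The step changes the ring and adds the methoxy group together, so its two parts cannot be separated; plain phenyl would divide them. Also open, going by these compounds, is whether 3-chlorophenyl or 3-hydroxyphenyl would match 3-methoxyphenyl at this position.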